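Methyl in place of fluoro on the aryl of compound 1

A few compounds are considered here, and "the series" means these few. Any claim that something is new, unique, unknown or untested is made for them only; others in the source may bear on it.

Measured compounds, read in a functional assay on HeLa cells (Homo sapiens) for inhibition, read by MTT assay, with a stated time of 24 h; on this read-out higher numbers stand for weaker inhibition and lower numbers for stronger inhibition:
Compound 1 `CCOC(=O)C1=Cc2ccccc2OC1(OCc1cn(-c2ccc(F)cc2)nn1)C(F)(F)F`: 8400 nM
Compound 2 `CCOC(=O)C1=Cc2ccccc2OC1(OCc1cc(-c2ccc3ccccc3c2)no1)C(F)(F)F`: a limit of the assay, > 150000 nM
Compound 3 `CCOC(=O)C1=Cc2ccccc2OC1(OCc1cc(-c2ccc(OC)cc2)no1)C(F)(F)F`: a limit of the assay, > 150000 nM

Among the measured compounds shown here, compound 1 stands as the only compound of the three with a number in this assay; the other two values are limits, as noted in the limit of > 150000 nM in this assay, at which 2 of the 3 values shown sit. For the measured compounds named here, the one step between measured compounds, a step that the two limits leave unreadable from compound 2 to compound 3, runs between two limits and gives no readable size. It also concerns the other arm of the shared core and so does not touch the change considered here.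

Compound 4 `CCOC(=O)C1=Cc2ccccc2OC1(OCc1cn(-c2ccc(C)cc2)nn1)C(F)(F)F` differs from compound 1 by methyl in place of fluoro on an aromatic carbon. Going by the values given here, no measured step bears on this exchange, so no direction can be taken from the data; the working expectation is a step within the usual scatter of this assay.

Compound 4 is therefore expected to give 8400 nM, with a range from 3000 nM to 25000 nM. The step this estimate means, no change at the digits printed from compound 1 to compound 4 (within the scatter), is expected to stay within scatter.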

Compound 4, half-maximal inhibitory concentration: 25100 nM
Estimate against measurement, compound 4: 3.0-fold (0.48 log units) below; measured number outside the range, above it.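

In this assay, the position on the aromatic carbon para to a large group responds to a one-atom exchange: methyl in place of fluoro gives a 3.0-fold higher number from compound 1 to compound 4 (0.48 log units; beyond the scatter). Among the compounds shown here, this is the first readable step, as the earlier compounds offered a single number and a step between two limits that could not be read, and it runs toward weaker inhibition, with the 4-fluorophenyl compound the stronger of this pair. For the compounds shown here, nothing measured so far gives a reason for the step, which stands here as an observation only.

From the compounds shown here alone, one exchange at one position gives no ordering of groups, so it remains open how a chloro, an amine or a carboxylic acid at this place would read, and whether any group would take the number below that of compound 1. Also open, going by these compounds, is whether the same exchange would have a similar effect on the other arm of the shared core, where compound 2 and compound 3 give only limits of the assay.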